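The source may report more compounds than this note shows. Statements on the series, on what has been measured and on what is new or still open speak of the compounds shown alone.

In a functional assay on KM12 cells (Homo sapiens) for inhibition, read by sulforhodamine B assay, with a stated time of 96 h (a higher number here means a weaker inhibitor of growth, a lower number a stronger inhibitor of growth), compound 1 `CC[C@@H](Nc1nc(NCc2ccccn2)c2ncn(C(C)C)c2n1)C(C)(C)O` gives > 50000 nM, which is a limit of the assay and not a number. Its two measured relatives are compound 2 `CC[C@@H](Nc1nc(NCc2ccccn2)c2ncn(C(C)C)c2n1)C(C)O` at 37000 nM and compound 3 `CC[C@H](Nc1nc(NCc2ccccn2)c2ncn(C(C)C)c2n1)C(C)(C)O` at 38000 nM. Compound 4 `CCC(O)[C@H](CC)Nc1nc(NCc2ccccn2)c2ncn(C(C)C)c2n1` keeps the shared core and alters only the chain on the nitrogen: 1-ethyl-2-hydroxybutyl in place of 1-(1-hydroxy-1-methylethyl)propyl on a nitrogen on an aromatic ring. The two compounds have the same atoms, joined differently. Among the measured compounds shown here, no measured step makes this exact change. The closest are an at least 1.3-fold lower number from compound 1 to compound 2 (0.13 log units; that floor lies within the scatter), which alters the same chain, and an at least 1.3-fold lower number from compound 1 to compound 3 (0.11 log units; that floor lies within the scatter), which alters only its configuration as drawn. Both are floors that rest on (the limit of > 50000 nM in this assay, at which 1 of the 3 values shown sits), and both lie within the scatter. The remaining step, a 1.0-fold higher number from compound 2 to compound 3 (0.01 log units; within the scatter), also lies within the scatter. On this evidence, no clear change beyond the scatter is expected in this assay, and any shift would more likely be towards a lower number. The expected change is an at least 1.4-fold lower number from compound 1 to compound 4 (0.15 log units; that floor lies within the scatter). For compound 4 the estimated value is 35000 nM, with an expected range from 15000 nM to 60000 nM.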

Compound 4, concentration for 50% growth inhibition: > 50000 nM
Compound 4 was reported as a limit (the forecaster's own chance of this, stated with the estimate: 35%); at least 1.4-fold (0.15 log units) between middle value and limit.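

In this assay compound 4 gives > 50000 nM, which is a limit of the assay and not a number. On these data alone, with the 1-ethyl-2-hydroxybutyl chain on the nitrogen, the result is an at least 1.3-fold higher number from compound 3 to compound 4 (0.11 log units; that floor lies within the scatter) and an at least 1.3-fold higher number from compound 2 to compound 4 (0.13 log units; that floor lies within the scatter); both are floors within the scatter, so rejoining the same atoms of this chain gives no readable gain in growth inhibition, and the true size of either step stays unknown. The step from compound 1 to compound 4 cannot be read, because both compounds are reported only as limits: the limit of > 50000 nM in this assay, at which 2 of the 4 values shown sit.

The compounds shown leave open whether any chain at this place can give a number clearly lower than those seen here. They also leave open how a chain carrying an amine or a carboxylic acid in place of the hydroxy group would behave in this assay.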